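The compounds below may be only part of what the source reports. "The series", "measured", "known", "first", "only" and "open" are said of these compounds alone.

Three measured compounds share one core and differ only in the substituted phenyl group on the chain: compound 1 `COc1ccc(/C=C/CCCOc2cc(/C=C\c3cc(OC)c(OC)c(OC)c3)ccc2OC)cc1` carries 4-methoxyphenyl, compound 2 `COCOc1cccc(/C=C/CCCOc2cc(/C=C\c3cc(OC)c(OC)c(OC)c3)ccc2OC)c1` carries 3-(methoxymethoxy)phenyl, and compound 3 `COCOc1ccc(/C=C/CCCOc2cc(/C=C\c3cc(OC)c(OC)c(OC)c3)ccc2OC)cc1` carries 4-(methoxymethoxy)phenyl. In an ADME assay on HEK293 cells (Homo sapiens) for inhibition, read by MTT assay, with a stated time of 3 days (on this read-out lower numbers stand for stronger inhibition and higher numbers for weaker inhibition), compound 1 gives 88000 nM, compound 2 gives 30000 nM and compound 3 gives 25000 nM. Compound 3 therefore stands at the low end of these numbers, level with compound 2 within the scatter, while compound 1 lies clearly higher.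

Compound 4 `COc1ccc(/C=C\c2cc(OC)c(OC)c(OC)c2)cc1OCCC/C=C/c1ccc(F)cc1` keeps the core but changes that group: fluoro in place of methoxymethoxy on an aromatic carbon. This puts fluoro in place of methoxymethoxy on an aromatic carbon, para to a large group.

For the measured compounds named here, no fluoro compound has been measured, so the closest guide is the steps at this same phenyl group. The data show a 3.5-fold lower number from compound 1 to compound 3 (0.55 log units; beyond the scatter) and a 2.9-fold lower number from compound 1 to compound 2 (0.47 log units; beyond the scatter), both modest, while a 1.2-fold lower number from compound 2 to compound 3 (0.08 log units; within the scatter) stays within the scatter. Going by the values given here, compound 1, the only measured compound without a methoxymethoxy group, sits at the higher end, which suggests that losing this group may raise the number somewhat. The expected change is a 2.0-fold higher number from compound 3 to compound 4 (0.30 log units; within the scatter), a modest step toward weaker inhibition in this assay, though this is uncertain. Compound 4 is expected to give about 50000 nM, within an estimated range of 18000 nM to 130000 nM.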

Compound 4, half-maximal inhibitory concentration: 115000 nM
Compound 4: middle estimate off by 2.3-fold (0.36 log units), on the low side; the measured number falls inside the stated range.
By their numbers in this assay, from the lowest: compounds 3 and 2 (each within the scatter of the next); then compounds 1 and 4 (each within the scatter of the next).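

In this assay, for the compounds shown here, putting fluoro in place of methoxymethoxy on the aromatic carbon para to a large group gives a 4.6-fold higher number from compound 3 to compound 4 (0.66 log units; beyond the scatter) and this is the first direct look at removing methoxymethoxy from that carbon in favour of a group other than methoxy. The 4-fluorophenyl group also compares unfavourably with 3-(methoxymethoxy)phenyl, with a 3.8-fold higher number from compound 2 to compound 4 (0.58 log units; beyond the scatter) so both compounds carrying methoxymethoxy have lower numbers than the fluoro compound, whichever of the two places that group occupies. Fluoro and methoxy, by contrast, cannot be told apart here, as a 1.3-fold higher number from compound 1 to compound 4 (0.12 log units; within the scatter) stays within the scatter, and across these four compounds the two without methoxymethoxy sit together at the higher end, while nothing shown gives a measured reason for this split.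

The compounds shown leave open whether the lower numbers need the whole methoxymethoxy group or would persist with a hydroxy group or a longer ether chain such as ethoxymethoxy on that carbon. They also leave open whether an amine or a carboxylic acid there would follow the fluoro and methoxy compounds or the methoxymethoxy compounds.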